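Step from compound 1 to compound 4 in the series

The compounds below may be only part of what the source reports. "The series", "measured", "known", "first", "only" and "open" are said of these compounds alone.

Compound 1 `CN(c1ccccc1)c1cnc(NCc2c(F)ccc3c2CCO3)n2cnnc12` carries methyl(phenyl)amino on the shared core. Going by the values given here, in a physicochemical assay for lipophilicity, using the shake flask method, in phosphate buffer, measured as octanol-water partition, with a stated time of 30 min, at pH 7.4 (on this read-out lower numbers stand for lower lipophilicity and higher numbers for higher lipophilicity), compound 1 gives 3.6, the highest of the three numbers so far. Compound 3 `Cc1ncccc1-c1cnc(NCc2c(F)ccc3c2CCO3)c2ncc(=O)[nH]c12` comes nearest: in this assay compound 3 gives 2.8, a gap beyond the scatter. Compound 2 `Cn1nccc1-c1cnc(NCc2c(F)ccc3c2CCO3)c2cn[nH]c(=O)c12` lies furthest away; in this assay compound 2 gives 2.6, again beyond the scatter. Among the compounds with values here, compounds 2 and 3 differ from compound 1 in more than one place, so no single step connects any pair of the measured compounds.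

Compound 4 `C[C@H]1CC(=O)N(c2cnc(NCc3c(F)ccc4c3CCO4)n3cnnc23)C1` is the next compound for this assay. It differs from compound 1 in one place: 4-methyl-2-oxopyrrolidin-1-yl in place of methyl(phenyl)amino on an aromatic carbon. The group that leaves holds one six-membered aromatic ring of carbon only; the group that enters is one five-membered non-aromatic ring with 1 hetero atom and carries 1 double bond outside aromatic rings. Within the data shown here, no measured step of this kind exists in the set, so the expectation rests on compound 1 alone, whose starting point is 3.6. A drop in this assay beyond the scatter is expected, with the step from compound 1 to compound 4 estimated at a number 1.60 log units lower from compound 1 to compound 4 (beyond the scatter). Compound 4 is accordingly expected to give 2 in this assay, within a range of 1.3 to 2.7.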

Compound 4, distribution coefficient: 1.8
The estimate for compound 4 lay 0.20 log units above the measured number; the measured number falls inside the stated range.
By their numbers in this assay, from the lowest: compound 4; then compounds 2 and 3 (each within the scatter of the next); then compound 1.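

In this assay, going by these compounds alone, this is the first single change that can be read, and replacing methyl(phenyl)amino with 4-methyl-2-oxopyrrolidin-1-yl on an aromatic carbon of the six-membered aromatic ring with 2 nitrogen gives a number 1.80 log units lower from compound 1 to compound 4 (beyond the scatter) at this position. The exchange removes one six-membered aromatic ring of carbon only and brings in one five-membered non-aromatic ring with 1 hetero atom and 1 double bond outside aromatic rings, while the hydrogen-bond donor and acceptor counts and the absence of net charge stay the same, so those counts do not separate the two groups. No measurement here accounts for the size of the step.

This single step cannot separate the loss of the aromatic ring from the gain of the carbonyl, the smaller heavy-atom count or the added methyl and its defined stereocentre. Values for cyclohexyl(methyl)amino, which keeps the open amine with a saturated ring, and for the unmethylated 2-oxopyrrolidin-1-yl at the same place would begin to divide the step among these parts.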